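Replacing a Fluorophenyl with a Methoxyphenyl on a Shared Core

A few compounds are considered here, and "the series" means these few. Any claim that something is new, unique, unknown or untested is made for them only; others in the source may bear on it.

Of the compounds shown here, three built on one shared core have been measured in a functional assay (muscle tissue) with Cavia porcellus as the target; a higher number here means that more compound is needed for the effect, a lower number that less compound is needed. Compound 1 `COC(=O)C1=C(C)N=C(C)/C(=C(\O)OC)C1c1cccc([N+](C)(C)C)c1` gives 50100 nM, compound 2 `COC(=O)C1=C(C)N=C(C)/C(=C(\O)OC)C1c1c(Cl)cccc1Cl` gives 1.91 nM, and compound 3 `COC(=O)C1=C(C)N=C(C)/C(=C(\O)OC)C1c1ccc(F)cc1` gives 129 nM. Compound 3 therefore stands second highest of the three numbers: its nearest neighbour is compound 2, which lies far below it, while compound 1 lies much further above it. Going by the values given here, the only step measured between two compounds that differ in a single place is a 68-fold higher number from compound 2 to compound 3 (1.83 log units; beyond the scatter).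

Compound 4 `COC(=O)C1=C(C)N=C(C)/C(=C(\O)OC)C1c1cccc(OC)c1` differs from compound 3 in that same region of the molecule: 3-methoxyphenyl in place of 4-fluorophenyl on a saturated ring carbon. Among the compounds with values here, the step from compound 2 to compound 3 is the one measured change that bears on this, and it is large, showing that the aromatic group on the saturated ring carbon can shift the number a long way. It does not, however, fix a direction for 3-methoxyphenyl, so the expectation is a step of moderate size, probably toward a lower number but not far beyond the scatter. Compound 4 is estimated at 40 nM, with a range from 8 nM to 200 nM. The expected step is a 3.2-fold lower number from compound 3 to compound 4 (0.51 log units; beyond the scatter).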

Compound 4, half-maximal effective concentration: 191 nM
The estimate for compound 4 lay 4.8-fold (0.68 log units) below the measured number; the measured number falls inside the stated range.
By their numbers in this assay, from the lowest: compound 2; then compounds 3 and 4 (each within the scatter of the next); then compound 1.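

In this assay, 3-methoxyphenyl in place of 4-fluorophenyl on the saturated ring carbon gives a 1.5-fold higher number from compound 3 to compound 4 (0.17 log units; within the scatter) so a change of both the substituent and its place on the aromatic ring produces no readable difference between this pair. The distance to the dichlorinated compound is about as wide, with a 100-fold higher number from compound 2 to compound 4 (2.00 log units; beyond the scatter) so among the three compounds carrying neutral aromatic groups, the 2,6-dichlorophenyl of compound 2 alone stands apart, while compound 3 and compound 4 stay together. The comparison with the charged compound adds a second wide step at this aromatic group, with a 260-fold lower number from compound 1 to compound 4 (2.42 log units; beyond the scatter) showing that the methoxy group and the trimethylammonium group on that aromatic carbon give very different numbers. Nothing available explains any of these steps.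

The compounds shown leave open whether a single chlorine on the aromatic ring would stay with compound 3 and compound 4 or move toward compound 2. They also leave open where an amine or a carboxylic acid in place of the methoxy group would fall relative to compound 4 and compound 1.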